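Chloro for trifluoromethyl on the shared core: compound 4

The source may report more compounds than this note shows. Statements on the series, on what has been measured and on what is new or still open speak of the compounds shown alone.

Measured so far in an assay on Jurkat cells for activation of nuclear factor NF-kappa-B complex (Homo sapiens); a higher number here means a weaker inhibitor, a lower number a stronger inhibitor:
Compound 1, `O=C(Nc1cc(C(F)(F)F)cc(C(F)(F)F)c1)c1cnc(C(F)(F)F)nc1Cl`, reaches only the limit > 10000 nM.
Compound 2, `O=C(Nc1cc(C(F)(F)F)cc(C(F)(F)F)c1)c1cnc(C(F)(F)F)nc1C(F)(F)F`, likewise gives only the limit > 10000 nM.
Compound 3, `O=C(Nc1cc(C(F)(F)F)cc(C(F)(F)F)c1)c1cnc(-c2ccccc2)nc1`, also stops at the limit > 10000 nM.

Among the measured compounds shown here, compound 2 therefore stands at the limit of this assay, and the two other values shown are limits as well, so no compound here yet gives a number. For the measured compounds named here, the one single-point step, a step that the two limits leave unreadable from compound 1 to compound 2, cannot be read for size or direction because both of its ends sit at the limit of > 10000 nM in this assay, at which 3 of the 3 values shown sit.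

Compound 4, `O=C(Nc1cc(C(F)(F)F)cc(C(F)(F)F)c1)c1cnc(Cl)nc1C(F)(F)F`, differs from compound 2 by chloro in place of trifluoromethyl on an aromatic carbon. Going by the values given here, the only measured step touching the same pair of groups is the step from compound 1 to compound 2, and it is unreadable; it offers no direction. Among the compounds with values here, compound 1 carries the chloro at another place on the core and still sits at the limit, and compound 3 with its phenyl does the same, so the whole series so far is flat at the limit.

The expectation is that compound 4 stays with the others: a step that the limit leaves unreadable from compound 2 to compound 4 from compound 2 is estimated, not beyond the scatter. Compound 4 is estimated at 20000 nM, within 5000 nM to 100000 nM, most likely reported as a limit.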

Compound 4, half-maximal inhibitory concentration: 50 nM
Compound 4: middle estimate off by 400-fold (2.60 log units), on the high side; the whole stated range lies above it.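

In this assay, among the compounds shown here, replacing trifluoromethyl with chloro on the aromatic carbon between two ring nitrogen atoms gives an at least 200-fold lower number from compound 2 to compound 4 (2.30 log units; beyond the scatter), the first readable step, and it lies beyond the scatter; the other step cannot be read, since both of its ends are limits. The series is therefore not flat across the shared core: this one place, para to a large group and meta to a trifluoromethyl group, is enough on its own to separate a compound at the limit from one with a measured value. The step size is a bound rather than a measured gap, because compound 2 gives only a limit and not a number: the limit of > 10000 nM in this assay, at which 3 of the 4 values shown sit.

As far as these compounds go, what remains open is whether chloro is specifically required at this place or whether trifluoromethyl is simply not tolerated there, and a single pair cannot distinguish these two readings. Bromo, methyl, methoxy or an amine at the same place, with the rest of compound 4 unchanged, would show how narrow this requirement is.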